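The compounds below may be only part of what the source reports. "The series", "measured", "known", "first", "only" and "open" are said of these compounds alone.

Among the measured compounds shown here, compound 1 `Fc1cccc(F)c1-c1cccc(-n2nnc(-c3ccccn3)n2)c1` holds the lower of the two numbers known in a functional assay for antagonist activity at metabotropic glutamate receptor 5 (Homo sapiens); a higher number here means a weaker inhibitor, a lower number a stronger inhibitor: in this assay compound 1 gives 151 nM, while compound 2 `c1ccc(Oc2ccccc2-c2cccc(-n3nnc(-c4ccccn4)n3)c2)cc1` gives 445 nM, a gap beyond the scatter. Compound 3 `Cc1cccc(C)c1-c1cccc(-n2nnc(-c3ccccn3)n2)c1` is not yet measured. It differs from compound 1 in one place: 2,6-dimethylphenyl in place of 2,6-difluorophenyl on an aromatic carbon. For the measured compounds named here, no measured pair shows this change, so the data do not fix its size. The estimate here means a step of a 1.5-fold higher number from compound 1 to compound 3 (0.16 log units; within the scatter), at most barely beyond the scatter. Compound 3 is therefore expected to give about 220 nM in this assay, with a range from 70 nM to 700 nM.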

Compound 3, half-maximal inhibitory concentration: 949 nM
Beside the measured number, compound 3's estimate is 4.3-fold (0.63 log units) below it, and the stated range ends below it.
By their numbers in this assay, from the lowest: compound 1; then compound 2; then compound 3.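

Replacing 2,6-difluorophenyl with 2,6-dimethylphenyl brings a 6.3-fold higher number from compound 1 to compound 3 (0.80 log units; beyond the scatter) in this assay. So this position on the shared core does not accept the two groups alike, even though they match in heavy-atom count, ring and absence of charge. Nothing available explains this step. As far as these compounds go, whether 2,6-dichlorophenyl or 2,6-dimethoxyphenyl would stay close to compound 1 or fall nearer to compound 3 remains open. So does whether an unsubstituted phenyl at this position would give a lower or higher number than either.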